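Restoring a ring-bearing side chain after a dead-end cut

This account rests on a few compounds, and the source may have more. Where it says the series, first, only, none or still open, it means among the compounds named here.

Compound 2 `CC(C)(CCN)CN(C[C@H]1Cc2ccccc2CN1)[C@H]1CCCc2cccnc21` sits at the limit of a functional assay on cells for antagonist activity at C-X-C chemokine receptor type 4 (Homo sapiens), read by fluorescence and calcium flux, with stated times of 25 min and 90 s (a higher number here means a weaker inhibitor, a lower number a stronger inhibitor), reporting only > 33300 nM and no number. Compound 1 `c1ccc2c(c1)CN[C@@H](CN(CCCCNC1CCCCC1)[C@H]1CCCc3cccnc31)C2` gives 75.2 nM in this assay. For the measured compounds named here, the step of an at least 440-fold higher number from compound 1 to compound 2 (2.64 log units; beyond the scatter) is the one measured change that bears on the present question, and its size follows from the limit of > 33300 nM in this assay, at which 1 of the 2 values shown sits. Compound 3 `C(=C/CN(C[C@H]1Cc2ccccc2CN1)[C@H]1CCCc2cccnc21)\CNCc1cccnc1` reverses the direction of that cut: a group of 11 heavy atoms (9 carbon, 2 nitrogen; one six-membered aromatic ring with 1 hetero atom) in place of a group of 6 heavy atoms (5 carbon, 1 nitrogen; no ring), on a saturated chain carbon bound to an amine nitrogen. A large return toward the range of compound 1 is therefore expected, as the step of an at least 130-fold lower number from compound 2 to compound 3 (2.12 log units; beyond the scatter). Compound 3 is estimated at 250 nM, with a range from 30 nM to 3000 nM.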

Compound 3, half-maximal inhibitory concentration: 92.8 nM
Estimate against measurement, compound 3: 2.7-fold (0.43 log units) above; the range from low to high includes it.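

Restoring a ring on a saturated chain carbon bound to an amine nitrogen recovers the activity lost in the cut, an at least 350-fold lower number from compound 2 to compound 3 (2.55 log units; beyond the scatter). Compound 2 stands at a limit, not a number, so that step has only a lower bound: the limit of > 33300 nM in this assay, at which 1 of the 3 values shown sits. The six-membered aromatic ring with 1 hetero atom and the six-membered non-aromatic ring of carbon only are not told apart here, a 1.2-fold higher number from compound 1 to compound 3 (0.09 log units; within the scatter).

Going by these compounds, compound 3 also brings 1 double bond outside aromatic rings, so the ring's share in the return remains open. Also open, on these data alone, is how a phenyl ring or a longer saturated chain would read in this assay.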